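Removing the Chlorine from Compound 2

The source may report more compounds than this note shows. Statements on the series, on what has been measured and on what is new or still open speak of the compounds shown alone.

Compound 2 `Fc1ccc2nc(NC(=S)Nc3ccc(Cl)cc3)sc2c1` is tested in a functional assay on THP-1 cells (Homo sapiens) for cytotoxicity, read by MTT assay, with a stated time of 48 h (a lower number here means a stronger inhibitor, a higher number a weaker inhibitor), where compound 2 gives 31200 nM. Compound 1 `S=C(Nc1ccc(Cl)cc1)Nc1nc2ccccc2s1` gives 39000 nM, and compound 3 `c1ccc2sc(Nc3nc4ccccc4s3)nc2c1` gives 28800 nM; compound 2 thus stands second highest of the three numbers, with both others within the scatter of it. Going by the values given here, the only single-point step measured, a 1.3-fold lower number from compound 1 to compound 2 (0.10 log units; within the scatter), touched a different ring and stayed within the scatter. Compound 4 `Fc1ccc2nc(NC(=S)Nc3ccccc3)sc2c1` differs from compound 2 by hydrogen in place of chloro on an aromatic carbon. Among the compounds with values here, no measured step removes this chloro, and compounds 2 and 3 differ in many places, so their values only show that a larger change also stayed within the scatter. The expected step is therefore a 1.1-fold higher number from compound 2 to compound 4 (0.05 log units; within the scatter), no change beyond the scatter. Compound 4 is expected near 35000 nM, within 15000 nM to 80000 nM.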

Compound 4, half-maximal inhibitory concentration: 46600 nM
Compound 4: middle estimate off by 1.3-fold (0.12 log units), on the low side, and the stated range covers the measured number.
By their numbers in this assay, from the lowest: compounds 3, 2, 1 and 4 (each within the scatter of the next).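

In this assay, going from 4-chlorophenyl to phenyl gives a 1.5-fold higher number from compound 2 to compound 4 (0.17 log units; within the scatter), the first step shown on this ring rather than on the fluoro-bearing side of the molecule. Compound 2 and compound 4 therefore cannot be told apart, and the chloro is not shown to matter for this reading. Nothing available explains the result. Still open, going by these compounds, is whether an amine, a carboxylic acid or a longer chain at this same place on the ring would move the number beyond the scatter.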